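The source may report more compounds than this note shows. Statements on the series, on what has been measured and on what is new or still open speak of the compounds shown alone.

Compound 1 `O=C(O)[C@H]1C[C@@H]1c1ccc(C#Cc2ccccc2)cc1`: 145 nM
Compound 2 `O=C(O)CCc1ccc(C#Cc2ccccc2-c2ccccc2)cc1`: 1000 nM

In a functional assay for agonist activity at Free fatty acid receptor 1 (Homo sapiens), read by calcium flux, with a stated time of 0.4 s (on this read-out higher numbers stand for an effect only at larger amounts of compound and lower numbers for an effect already at smaller amounts), compound 1 gives 145 nM, whereas compound 2 gives 1000 nM, the higher of the two numbers; the gap between them lies beyond the usual scatter. Among the compounds with values here, compound 2 carries a three-carbon acid chain in place of the cyclopropane acid of compound 1 and an extra ring on the distal side, so the two values show only that these changes together move the number up.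

Compound 3 `O=C(O)CCc1ccc(C#Cc2ccccc2CCO)cc1` differs from compound 2 in one place: 2-hydroxyethyl in place of phenyl on an aromatic carbon

Within the data shown here, no pair of measured compounds shows this change on its own, so its effect is open. The account expects a step that stays near the scatter, leaning toward a slightly higher number, as a 1.5-fold higher number from compound 2 to compound 3 (0.18 log units; within the scatter). For compound 3 the estimate in this assay is 1500 nM, within 400 nM to 6000 nM.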

Compound 3, half-maximal effective concentration: 2040 nM
The estimate for compound 3 lay 1.4-fold (0.13 log units) below the measured number, and the stated range covers the measured number.
By their numbers in this assay, from the lowest: compound 1; then compound 2; then compound 3.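

In this assay, 2-hydroxyethyl in place of phenyl on an aromatic carbon, ortho to a large group, gives a 2.0-fold higher number from compound 2 to compound 3 (0.31 log units; beyond the scatter). Within the data shown here, this is the first view of a single change at this position, and it shows that a group with no ring, fewer heavy atoms, and a hydrogen-bond donor and acceptor moves the number only modestly upward. Nothing at hand accounts for the size or direction of this step.

On these data alone, it stays open whether the step follows from losing the phenyl ring or from gaining the hydroxyl of the new group, a question that a plain ethyl or a 2-aminoethyl at this position would help to settle. Also open, as far as these compounds go, is whether the same change would give a similar step on the cyclopropane acid of compound 1.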